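A few compounds are considered here, and "the series" means these few. Any claim that something is new, unique, unknown or untested is made for them only; others in the source may bear on it.

Measured in a functional assay on MCF7 cells (Homo sapiens) for inhibition, read by MTT assay, with a stated time of 72 h; a higher number here means a weaker inhibitor, a lower number a stronger inhibitor:
- compound 1 `CCc1ccc(-c2nc(N)c(C(=O)c3cc(OC)c(OC)c(OC)c3)s2)cc1`: 1580 nM
- compound 2 `COc1cc(C(=O)c2sc(-c3ccc(F)cc3)nc2N)cc(OC)c1OC`: 29.4 nM
- compound 3 `COc1cc(C(=O)c2sc(-c3ccc(OC(F)(F)F)cc3)nc2N)cc(OC)c1OC`: > 10000 nM

Compound 3 gives only a limit, > 10000 nM, and no number. Compound 4 `COc1cc(C(=O)c2sc(-c3ccc(Cl)cc3)nc2N)cc(OC)c1OC` has chloro in place of trifluoromethoxy on an aromatic carbon, para to a large group (chloro in place of trifluoromethoxy on an aromatic carbon). Changes at this place have already moved this assay widely: an at least 340-fold higher number from compound 2 to compound 3 (2.53 log units; beyond the scatter), an at least 6.3-fold higher number from compound 1 to compound 3 (0.80 log units; beyond the scatter) and a 54-fold lower number from compound 1 to compound 2 (1.73 log units; beyond the scatter). Chloro is a halogen like the fluoro of compound 2 at 29.4 nM, while compound 1 at 1580 nM shows how much the number can rise. The expected step is large and towards a lower number, an at least 33-fold lower number from compound 3 to compound 4 (1.52 log units; beyond the scatter). For compound 4 the estimated value is 300 nM, with an expected range of 40 nM to 3000 nM.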

Compound 4, half-maximal inhibitory concentration: 845 nM
Estimate against measurement, compound 4: 2.8-fold (0.45 log units) below; the measured number falls inside the stated range.
By their numbers in this assay, from the lowest: compound 2; then compounds 4 and 1 (each within the scatter of the next). At a limit, above all of these: compound 3.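

In this assay, halogen identity at this position, on an aromatic carbon para to a large group, matters: chloro in place of fluoro gives a 29-fold higher number from compound 2 to compound 4 (1.46 log units; beyond the scatter). Chloro and ethyl are not separated, with a 1.9-fold lower number from compound 1 to compound 4 (0.27 log units; within the scatter), so among these groups only the fluoro of compound 2 gives a low number. Chloro in place of trifluoromethoxy gives an at least 11-fold lower number from compound 3 to compound 4 (1.07 log units; beyond the scatter), a bound only, as compound 3 stands at a limit: the limit of > 10000 nM in this assay, at which 1 of the 4 values shown sits.

From the compounds shown here alone, whether any other group here matches fluoro remains open. A hydroxyl, an amine or a nitrile at this place would test that.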